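A Pyrimidine Variant in a Series Showing No Binding

The source may report more compounds than this note shows. Statements on the series, on what has been measured and on what is new or still open speak of the compounds shown alone.

In an assay on HEK293 cells for binding affinity to Substance-K receptor (Rattus norvegicus), read by FRET, tested at 10 uM (on this read-out higher numbers stand for more inhibition at the one concentration tested (going by the name of the read-out) and lower numbers for less inhibition), compound 3 `c1ccc(CN(Cc2ccc3ccccc3c2)c2cccnc2)cc1` gives 0%. It stands level with compound 1 `C#CCN(Cc1ccccc1)Cc1ccc2ccccc2c1`, which gives 0%, and with compound 2 `CCCCNC(=O)CN(Cc1ccccc1)Cc1ccc2ccccc2c1`, which gives 0%. Every step among these three is flat: no change at the digits printed from compound 1 to compound 2 (within the scatter), while the two exchanges on the amine nitrogen give no change at the digits printed from compound 1 to compound 3 (within the scatter) and no change at the digits printed from compound 2 to compound 3 (within the scatter). Compound 4 `c1ccc(CN(Cc2ccc3ccccc3c2)c2ccncn2)cc1` differs from compound 3 by one change, (pyrimidin-4-yl in place of pyridin-3-yl on an amine nitrogen). For the measured compounds named here, the steps that bear on it are the two that also vary the group on that amine nitrogen, and neither moved the read-out beyond the scatter. Three different groups on the same nitrogen leave the read-out at the same level, so a further exchange of one six-membered aromatic ring for another is expected to yield no step beyond the scatter, an expected no change at the digits printed from compound 3 to compound 4 (within the scatter). Compound 4 is therefore estimated at 0%, with an expected range from -8% to 12%.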

Compound 4, a percentage reported as inhibition, at one concentration (the size of the read-out at that concentration, not a potency): 34%
Compound 4: middle estimate off by 34 percentage points, on the low side; measured number above the stated range.
By their numbers in this assay, from the lowest: compounds 1, 2 and 3 (each within the scatter of the next); then compound 4.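

In this assay pyrimidin-4-yl in place of pyridin-3-yl on the amine nitrogen gives a number 34 percentage points higher from compound 3 to compound 4 (beyond the scatter) while both groups remain one six-membered aromatic ring of 6 heavy atoms and the hetero atoms go from 1 to 2. For the compounds shown here, the other exchanges tell the same story, with a number 34 percentage points higher from compound 2 to compound 4 (beyond the scatter) on replacing (butylcarbamoyl)methyl and a number 34 percentage points higher from compound 1 to compound 4 (beyond the scatter) on replacing propargyl on that nitrogen, so this position can move the read-out after all, which the earlier compounds did not show. Nothing at hand explains the rise.

Still open, going by these compounds, is whether the rise belongs to pyrimidin-4-yl alone or extends to other rings on that nitrogen, such as pyrimidin-5-yl, pyrazin-2-yl or pyridin-2-yl. Also open, on these data alone, is whether it survives an amino or methoxy group on the pyrimidine ring.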